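The source may hold more compounds than are shown below. What is called first, only, known or untested is meant among the compounds shown, and "the series" means these compounds.

Compound 3 `O=[N+]([O-])c1ccc(Nc2nc(SCc3ccc(C(F)(F)F)cc3)nc3ccccc23)cc1` gives 17900 nM in a functional assay on MCF7 cells (Homo sapiens) for cytotoxicity, read by MTT assay, with a stated time of 72 h (a lower number here means a stronger inhibitor, a higher number a weaker inhibitor), the lowest of the two plain numbers found here; compound 2 `Fc1ccc(Nc2nc(SCc3ccc(C(F)(F)F)cc3)nc3ccccc23)cc1` gives 36300 nM, and the step of a 2.0-fold lower number from compound 2 to compound 3 (0.31 log units; beyond the scatter) sets the two apart. For compound 1 `CCOc1ccccc1Nc1nc(SCc2ccc(C(F)(F)F)cc2)nc2ccccc12` this assay reports only a limit, > 50000 nM. Compound 4 `Cc1ccc(Nc2nc(SCc3ccc(C(F)(F)F)cc3)nc3ccccc23)cc1` carries methyl in place of nitro on an aromatic carbon. Within the data shown here, two measured steps bear on this change: a 2.0-fold lower number from compound 2 to compound 3 (0.31 log units; beyond the scatter), where nitro entered for fluoro, and an at least 2.7-fold lower number from compound 1 to compound 3 (0.44 log units; beyond the scatter), where 4-nitrophenyl entered for 2-ethoxyphenyl. Both point the same way, so removing the nitro is expected to undo a modest part of that gain, a 1.8-fold higher number from compound 3 to compound 4 (0.25 log units; within the scatter). Compound 4 is therefore estimated at 32000 nM, with a likely range from 12000 nM to 70000 nM.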

Compound 4, half-maximal inhibitory concentration: > 50000 nM
Compound 4 ended at the assay's limit (the forecaster's own chance of this, stated with the estimate: 25%); at least 1.5-fold (0.19 log units) between middle value and limit.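

Swapping nitro for methyl at this position costs activity by a margin that the earlier compounds did not show: an at least 2.7-fold higher number from compound 3 to compound 4 (0.44 log units; beyond the scatter). With fluoro in the same place, the step is an at least 1.3-fold higher number from compound 2 to compound 4 (0.13 log units; that floor lies within the scatter), so methyl and fluoro cannot be ordered. Compound 4 gives only a limit in this assay, and the step from compound 1, also a limit, cannot be read: the limit of > 50000 nM in this assay, at which 2 of the 4 values shown sit.

Still open, as far as these compounds go, is whether a nitrile or a carboxylic acid at this position would match nitro. An amine there is equally untested by the compounds shown.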